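From Aryl Sulfonyl to Cyanobenzyl: An Expected Cytotoxicity

The compounds below may be only part of what the source reports. "The series", "measured", "known", "first", "only" and "open" are said of these compounds alone.

Values in a functional assay on HeLa cells (Homo sapiens) for cytotoxicity, read by MTT assay, with a stated time of 48 h; a lower number here means a stronger inhibitor, a higher number a weaker inhibitor:
Compound 1 `CCN(CC)c1ccc2cc(C(=O)c3ccc(N4CCN(C(=O)CN5CCN(S(=O)(=O)c6ccc(OC(F)(F)F)cc6)CC5)CC4)cc3)oc2c1` gives 30200 nM.
Compound 2 `CCN(CC)c1ccc2cc(C(=O)c3ccc(N4CCN(C(=O)CN5CCN(S(=O)(=O)c6ccc(F)cc6)CC5)CC4)cc3)oc2c1` gives 16700 nM.

Compound 2 cannot be separated from compound 1 on these numbers, because the step of a 1.8-fold lower number from compound 1 to compound 2 (0.26 log units; within the scatter) lies within the scatter. Compound 3 `CCN(CC)c1ccc2cc(C(=O)c3ccc(N4CCN(C(=O)CN5CCN(Cc6ccc(C#N)cc6)CC5)CC4)cc3)oc2c1` differs from compound 2 by 4-cyanobenzyl in place of (4-fluorophenyl)sulfonyl on an amine nitrogen in a ring. Within the data shown here, the only measured step, a 1.8-fold lower number from compound 1 to compound 2 (0.26 log units; within the scatter), exchanged one group on the aromatic ring of the sulfonyl and stayed within the scatter; no measured step removes the sulfonyl or introduces a benzyl, so nothing here points in a direction. Compound 3 is therefore expected to show a step of a 1.0-fold higher number from compound 2 to compound 3 (0.01 log units; within the scatter), with wide uncertainty. Compound 3 is estimated at 17000 nM, expected between 5000 nM and 60000 nM.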

Compound 3, half-maximal inhibitory concentration: > 40000 nM
Compound 3 gave a limit, no number; the forecaster's own chance of this, stated with the estimate: 10%; at least 2.3-fold (0.37 log units) between middle value and limit.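

In this assay, putting 4-cyanobenzyl in place of (4-fluorophenyl)sulfonyl on this amine nitrogen gives an at least 2.3-fold higher number from compound 2 to compound 3 (0.37 log units; beyond the scatter) and is the first step shown to lie beyond the scatter. Compound 3 gives > 40000 nM as a limit of the assay, not a number. The group on this nitrogen therefore moves the read-out, whereas the earlier exchange on the aromatic ring of the sulfonyl stayed within the scatter.

The sulfonyl and the fluoro both leave in this one step, so the compounds shown do not separate their parts. From the compounds shown here alone, whether a 4-fluorobenzyl or an acetyl on this nitrogen would read closer to compound 2 stays open.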